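Removing One Chloro from the Dichlorophenyl of Compound 3

The source may hold more compounds than are shown below. What is called first, only, known or untested is meant among the compounds shown, and "the series" means these compounds.

Compound 3 `COc1cc(/C=C/C(=O)C2=C(/C=C/c3ccc(O)c(OC)c3)NC(=O)NC2c2c(Cl)cccc2Cl)ccc1O` gives the lowest of the three numbers recorded so far in a functional assay, with a stated time of 20 min, tested at 10 uM (a lower number here means a weaker effect, a higher number a stronger effect of the compound at the concentration tested), namely 20%. Its nearest neighbour is compound 1 `COc1cc(/C=C/C(=O)C2=C(/C=C/c3ccc(O)c(OC)c3)NC(=O)NC2c2ccc(C)cc2)ccc1O`, which in this assay gives 23.9%; the step of a number 3.9 percentage points lower from compound 1 to compound 3 (within the scatter) lies within the scatter. Compound 2 `COc1cc(/C=C/C(=O)C2=C(/C=C/c3ccc(O)c(OC)c3)NC(=O)NC2c2ccccc2O)ccc1O` stands far apart, giving 71% in this assay, and the step of a number 51 percentage points lower from compound 2 to compound 3 (beyond the scatter) is large, as is a number 47.1 percentage points higher from compound 1 to compound 2 (beyond the scatter).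

Compound 4 `COc1cc(/C=C/C(=O)C2=C(/C=C/c3ccc(O)c(OC)c3)NC(=O)NC2c2ccccc2Cl)ccc1O` differs from compound 3 by hydrogen in place of chloro on an aromatic carbon. Among the measured compounds shown here, no measured step removes a single chloro, so none bears directly on this change. What the data show is that compound 2 with its 2-hydroxyphenyl gives 71%, whereas compound 1 with its 4-methylphenyl gives 23.9% and compound 3 with its 2,6-dichlorophenyl gives 20%. Compound 4 carries a 2-chlorophenyl without a hydroxy group, and the step of a number 8 percentage points higher from compound 3 to compound 4 (within the scatter) is therefore expected to stay within the scatter. Compound 4 is expected to give about 28% in this assay, within a range from 10% to 55%.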

Compound 4, a percentage reported as activity, at one concentration (the size of the read-out at that concentration, not a potency): 23%
For compound 4 the middle estimate is 5 percentage points above the measured one; low and high end bracket the measured number.
By their numbers in this assay, from the lowest: compounds 3, 4 and 1 (each within the scatter of the next); then compound 2.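

In this assay, removing one chloro from the 2,6-dichlorophenyl gives a number 3 percentage points higher from compound 3 to compound 4 (within the scatter) and so has no readable effect at this aromatic carbon. Among the compounds shown here, the direct exchange gives a number 48 percentage points lower from compound 2 to compound 4 (beyond the scatter) and ties the large gap to chloro in place of hydroxy on an aromatic carbon, a single-atom change that the earlier compounds did not isolate. The 2-chlorophenyl also gives a number 0.9 percentage points lower from compound 1 to compound 4 (within the scatter) and cannot be told apart from the 4-methylphenyl, while no measured evidence bears on why these steps take the sizes they do.

On these data alone, what remains open is whether the stronger read-out of compound 2 needs the hydroxy itself or would also appear with an amine or a methoxy on the same aromatic carbon. As far as these compounds go, whether a hydroxy on another carbon of this ring would do the same is also open.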